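The source may hold more compounds than are shown below. What is called first, only, known or untested is meant among the compounds shown, and "the series" means these compounds.

Working notes on the series. The shared core of compound 1 `O=C(CCCCCCc1ccccc1)c1ncc(-c2ccco2)s1` and compound 2 `O=C(CCCCCCc1ccccc1)c1ncc(-c2cccs2)s1` carries a five-membered ring with one nitrogen and one sulfur; compound 3 `O=C(CCCCCCc1ccccc1)c1nnc(-c2ccco2)s1` and the unmeasured compound 4 `O=C(CCCCCCc1ccccc1)c1nnc(-c2cccs2)s1` carry a ring with two nitrogens and one sulfur, and the difference between the two cores is not broken down here. In an assay for inhibition of Fatty-acid amide hydrolase 1 (Rattus norvegicus), at pH 9.0 (a higher number here means a weaker inhibitor, a lower number a stronger inhibitor), compound 1 gives 1500 nM, compound 2 gives 2000 nM and compound 3 gives 7.4 nM. The change thiophen-2-yl in place of furan-2-yl on an aromatic carbon gave a 1.3-fold higher number from compound 1 to compound 2 (0.12 log units; within the scatter). The change thiophen-2-yl in place of furan-2-yl on an aromatic carbon is the same kind of change, though the place differs: here the carbon is next to the ring nitrogen as well as next to the ring sulfur. Because compound 1 to compound 2 gave a 1.3-fold higher number from compound 1 to compound 2 (0.12 log units; within the scatter), a similarly small step is expected for compound 4, a 1.2-fold higher number from compound 3 to compound 4 (0.09 log units; within the scatter). Compound 4 is estimated at 9 nM, between 4 nM and 25 nM.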

Compound 4, inhibition constant: 27 nM
Estimate against measurement, compound 4: 3.0-fold (0.48 log units) below; measured number above the stated range.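

In this assay, thiophen-2-yl in place of furan-2-yl on an aromatic carbon gave a 3.6-fold higher number from compound 3 to compound 4 (0.56 log units; beyond the scatter). The size of this step did not carry over from one core to the other: the same change on two cores in this assay, a 1.3-fold higher number (0.12 log units; within the scatter) from compound 1 to compound 2 and a 3.6-fold higher number (0.56 log units; beyond the scatter) from compound 3 to compound 4, 2.7-fold (0.44 log units) apart, beyond the scatter of two such steps. With one pair on each core, this shows that a step read on the core of compound 1 need not predict its size on the core of compound 3, but it does not show why the two steps differ or how the change would behave on any further core.

Still open, on these data alone, is whether the same gap would appear with a different group on this aromatic carbon, such as phenyl or an amine. Also open, as far as these compounds go, is whether it would persist with a shorter chain on the carbonyl.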